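The source may report more compounds than this note shows. Statements on the series, on what has been measured and on what is new or still open speak of the compounds shown alone.

Values in a functional assay on HCT-116 cells (Homo sapiens) for inhibition, read by MTT assay, with a stated time of 48 h; a higher number here means a weaker inhibitor, a lower number a stronger inhibitor:
Compound 1 `COc1ccc(-c2cc(-c3cc(OC)c(OC)c(OC)c3)nc(-c3ccccc3)n2)c(OC)c1`: > 25000 nM (a limit of the assay, not a number)
Compound 2 `COc1cc(-c2cc(-c3ccccc3)nc(-c3ccccc3)n2)cc(OC)c1OC`: 9950 nM
Compound 3 `COc1ccc(-c2cc(-c3cc(OC)c(OC)c(OC)c3)nc(-c3ccccc3)n2)cc1`: 4780 nM

Compound 3 has the lower of the two actual numbers, with compound 2 nearest, while compound 1 gives only a limit. Compound 4 `COc1cc(-c2cc(-c3cccs3)nc(-c3ccccc3)n2)cc(OC)c1OC` carries thiophen-2-yl in place of 4-methoxyphenyl on an aromatic carbon of the shared core (thiophen-2-yl in place of 4-methoxyphenyl on an aromatic carbon). Within the data shown here, no measured compound carries thiophen-2-yl, so the evidence is indirect.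

The closest guide is compound 2, which has phenyl at this place. Methoxy in place of hydrogen on an aromatic carbon gives a 2.1-fold lower number from compound 2 to compound 3 (0.32 log units; beyond the scatter). Two further steps start from a limit and so give only bounds: an at least 2.5-fold lower number from compound 1 to compound 2 (0.40 log units; beyond the scatter) and an at least 5.2-fold lower number from compound 1 to compound 3 (0.71 log units; beyond the scatter). Both concern substitution on the same aryl position, but neither involves a five-membered ring.

Compound 4 lacks the methoxy group of compound 3, so a 2.1-fold lower number from compound 2 to compound 3 (0.32 log units; beyond the scatter) suggests a modest rise in the number in this assay, to roughly the level of compound 2. The expected change is a 1.6-fold higher number from compound 3 to compound 4 (0.20 log units; within the scatter). For compound 4 the estimated value is 7500 nM, with an expected range of 2500 nM to 20000 nM.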

Compound 4, half-maximal inhibitory concentration: 17000 nM
Beside the measured number, compound 4's estimate is 2.3-fold (0.36 log units) below it; low and high end bracket the measured number.
By their numbers in this assay, from the lowest: compound 3; then compounds 2 and 4 (each within the scatter of the next). At a limit, above all of these: compound 1.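

In this assay, thiophen-2-yl is the only five-membered aromatic ring at this position, and the swap from phenyl gives no difference that can be read: a 1.7-fold higher number from compound 2 to compound 4 (0.23 log units; within the scatter). The swap from 4-methoxyphenyl does register, a 3.6-fold higher number from compound 3 to compound 4 (0.55 log units; beyond the scatter), so a six-membered ring alone does not account for the low number of compound 3, since phenyl in compound 2 sits with thiophen-2-yl in compound 4 and the 4-methoxyphenyl group stands apart, though compound 1 goes against any simple gain from methoxy on this ring. The step that starts from a limit gives only a floor, an at least 1.4-fold lower number from compound 1 to compound 4 (0.16 log units; that floor lies within the scatter), and no order can be drawn from it; the limit belongs to compound 1 in this assay: the limit of > 25000 nM in this assay, at which 1 of the 4 values shown sits.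

Open, on these data alone, is whether methoxy on thiophen-2-yl would lower the number as it does on phenyl, and how furan-2-yl would compare with thiophen-2-yl at this position. Also open, as far as these compounds go, is how an amine or a carboxylic acid in place of the methoxy of compound 3 would read in this assay.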